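Opening the propyl ester chain of compound 1

The source may hold more compounds than are shown below. What is called first, only, known or untested is meant among the compounds shown, and "the series" means these compounds.

Measured compounds:
compound 1, `C/C=C1/[C@H](O[C@@H]2O[C@H](COC(C)=O)[C@@H](OC(C)=O)[C@H](OC(C)=O)[C@H]2OC(C)=O)OC=C(C(=O)OC)[C@H]1CC(=O)OCCC`: 6600 nM
compound 2, `C/C=C1/[C@H](O[C@@H]2O[C@H](CO)[C@@H](O)[C@H](O)[C@H]2O)OC=C(C(=O)OC)[C@H]1CC(=O)NCCC`: > 20000 nM
compound 3, `C/C=C1/[C@H](O[C@@H]2O[C@H](CO)[C@@H](O)[C@H](O)[C@H]2O)OC=C(C(=O)OC)[C@H]1CC(=O)OCc1ccccc1`: > 15000 nM

Within the data shown here, in a functional assay on SK-BR-3 cells (Homo sapiens) for antiproliferative activity, read by MTT assay, with a stated time of 72 h (a higher number here means a weaker inhibitor, a lower number a stronger inhibitor), compound 1 gives 6600 nM, the only number among the three values. The other two values are limits of the assay. For compound 2 the assay reports only a limit, > 20000 nM. For compound 3 it likewise reports only a limit, > 15000 nM. Among the measured compounds shown here, compound 1 therefore stands alone as the one compound with a read number, and no measured step places it above or below the others.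

Compound 4, `C=C(C)CCOC(=O)C[C@@H]1C(C(=O)OC)=CO[C@@H](O[C@@H]2O[C@H](COC(C)=O)[C@@H](OC(C)=O)[C@H](OC(C)=O)[C@H]2OC(C)=O)/C1=C/C`, differs from compound 1 by 1-methylethenyl in place of methyl on a saturated chain carbon, two bonds along the chain from an oxygen next to a carbonyl group. For the measured compounds named here, no measured step touches this kind of change: the only step in hand, a step that the two limits leave unreadable from compound 2 to compound 3, concerns the ester-to-amide exchange and cannot be read between the two limits the limit of > 15000 nM in this assay, at which 1 of the 3 values shown sits, and (the limit of > 20000 nM in this assay, at which 1 of the 3 values shown sits). With nothing to draw on, the expected step is none beyond the scatter, a 1.2-fold lower number from compound 1 to compound 4 (0.08 log units; within the scatter). Compound 4 is thus estimated at 5500 nM, between 2000 nM and 15000 nM, in this assay.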

Compound 4, half-maximal inhibitory concentration: > 15000 nM
Compound 4: a limit, no number; the forecaster's own chance of this, stated with the estimate: 15%; at least 2.7-fold (0.43 log units) between middle value and limit.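

With compound 4 the propyl ester chain gets its first readable step: in this assay, 1-methylethenyl in place of methyl on a saturated chain carbon, two bonds along the chain from an oxygen next to a carbonyl group, gives an at least 2.2-fold higher number from compound 1 to compound 4 (0.35 log units; beyond the scatter). Among these compounds, this position therefore does not accept the change from propyl to 3-methylbut-3-en-1-yl without a loss beyond the scatter, and compound 1 remains the only compound here with a read number. The reading of compound 4 is a limit of the assay, and that limit is shared: the limit of > 15000 nM in this assay, at which 2 of the 4 values shown sit.

From the compounds shown here alone, the true size of the loss stays open, since a limit gives no number. The compounds shown also leave open whether the added carbons or the double bond carry the loss, which a saturated 3-methylbutyl ester would address, and how an amine at the end of the propyl chain would read.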